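Thiophen-2-yl in Place of 2-Fluorophenyl on a Shared Core

This account rests on a few compounds, and the source may have more. Where it says the series, first, only, none or still open, it means among the compounds named here.

So far two compounds have numbers in a functional assay, with a stated time of 20 min (a higher number here means a weaker inhibitor, a lower number a stronger inhibitor), namely compound 1 (`CCOC(=O)c1cnn(-c2nc(-c3ccccc3F)c(C#N)c(=O)n2C)c1N`) at 69 ug/mL and compound 2 (`CSc1nc(-c2ccccc2O)c(C#N)c(=O)n1C`) at 52 ug/mL as its reading. These two values lie within the scatter of each other, so compound 1 stands level with compound 2 and the pair cannot be ranked. Going by the values given here, no two measured compounds differ in one place only, so no measured step bears on the next structure.

That structure is compound 3 (`CCOC(=O)c1cnn(-c2nc(-c3cccs3)c(C#N)c(=O)n2C)c1N`), which carries thiophen-2-yl in place of 2-fluorophenyl on an aromatic carbon, while the rest of compound 1 stays as it is (thiophen-2-yl in place of 2-fluorophenyl on an aromatic carbon). With no measured guide to this exchange, no step beyond the scatter is expected in this assay, and no direction can be argued with confidence. The estimated step, a 1.2-fold lower number from compound 1 to compound 3 (0.06 log units; within the scatter), stays within the scatter. Compound 3 is therefore estimated at 60 ug/mL with a range of 25 ug/mL to 140 ug/mL as its expected span.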

Compound 3, half-maximal inhibitory concentration: 79 ug/mL
Compound 3: middle estimate off by 1.3-fold (0.12 log units), on the low side; low and high end bracket the measured number.
By their numbers in this assay, from the lowest: compounds 2, 1 and 3 (each within the scatter of the next).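

In this assay, going by these compounds alone, the exchange of 2-fluorophenyl for thiophen-2-yl on the aromatic carbon next to the ring nitrogen and ortho to a cyano group gives a 1.1-fold higher number from compound 1 to compound 3 (0.06 log units; within the scatter) and so provides the first one-place comparison, with compound 3 standing level with compound 1. At this position, therefore, a five-membered aromatic ring with 1 hetero atom and a six-membered aromatic ring of carbon only cannot be told apart in this read-out, even though the two groups differ in their heavy atoms and in their count of hydrogen-bond acceptors. No accompanying measurement bears on this result, and the comparison offers no account of what lies behind it.

The compounds shown leave open whether any group on this carbon can produce a step beyond the scatter, since the only exchange available here joins two aromatic rings. An amine, a carboxylic acid or a longer chain at this position, or an unsubstituted phenyl that would separate the contribution of the fluorine, would test how far this level reading extends.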